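The source may report more compounds than this note shows. Statements on the series, on what has been measured and on what is new or still open speak of the compounds shown alone.

In a functional assay on the whole organism for inhibition, with Mythimna separata as the target, with a stated time of 5 days (a higher number here means that more compound is needed for the effect, a lower number that less compound is needed), compound 3 `CC(C)(C)n1ncc(OCc2nnc(-c3ccccc3F)s2)c(Cl)c1=O` gives 121000 nM and compound 1 `CC(C)(C)n1ncc(OCc2nnc(-c3cc(F)c(Cl)cc3Cl)s2)c(Cl)c1=O` gives 67100 nM, the two being separated by a 1.8-fold higher number from compound 1 to compound 3 (0.26 log units; within the scatter). Compound 2 `Cc1cc(C)cc(-c2nnc(COc3cnn(C(C)(C)C)c(=O)c3Cl)s2)c1` reads > 299000 nM, which is a limit of the assay. Against that limit, the steps are an at least 4.4-fold higher number from compound 1 to compound 2 (0.64 log units; beyond the scatter) and an at least 2.4-fold lower number from compound 2 to compound 3 (0.39 log units; beyond the scatter). Compound 4 `CC(C)(C)n1ncc(OCc2nnc(-c3ccc(F)cc3)s2)c(Cl)c1=O` carries 4-fluorophenyl in place of 2-fluorophenyl on an aromatic carbon. All three measured steps exchange the aryl group at this same place, but none shifts a single fluorine alone. Among the compounds with values here, only the step between compound 1 and compound 3 keeps a 2-fluoro group, and it stays within the scatter. The expected step is a 1.2-fold lower number from compound 3 to compound 4 (0.08 log units; within the scatter), so no change beyond the scatter is anticipated in this assay. For compound 4 the estimate is 100000 nM, with an expected range from 40000 nM to 250000 nM.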

Compound 4, half-maximal effective concentration: 21500 nM
Estimate against measurement, compound 4: 4.7-fold (0.67 log units) above; measured number outside the range, below it.
By their numbers in this assay, from the lowest: compound 4; then compounds 1 and 3 (each within the scatter of the next). At a limit, above all of these: compound 2.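

In this assay, within the data shown here, the step from 2-fluorophenyl to 4-fluorophenyl gives a 5.6-fold lower number from compound 3 to compound 4 (0.75 log units; beyond the scatter); it is the first step here that changes only where a single fluorine sits, and it shows that this alone moves the number beyond the scatter. The 4-fluorophenyl group also goes below the 2,4-dichloro-5-fluorophenyl group, with a 3.1-fold lower number from compound 1 to compound 4 (0.49 log units; beyond the scatter). Against the 3,5-dimethylphenyl group the step is an at least 13-fold lower number from compound 2 to compound 4 (1.14 log units; beyond the scatter), a bound only, that group's value being a limit: the limit of > 299000 nM in this assay, at which 1 of the 4 values shown sits.

On these data alone, it remains open whether a phenyl group without fluorine, or a methoxy group or an amine in place of that fluorine, would keep this lower number.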